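Cyano to methoxy on the benzyl group: series notes

The compounds below may be only part of what the source reports. "The series", "measured", "known", "first", "only" and "open" are said of these compounds alone.

Measured so far:
Compound 1 `N#Cc1ccc(Cn2cc(COc3ccc4c(=O)ccoc4c3)nn2)cc1` in a functional assay on SW480 cells (Homo sapiens) for cytotoxicity, read by MTT assay, with a stated time of 48 h (a higher number here means a weaker inhibitor, a lower number a stronger inhibitor), gives > 100000 nM, a limit of the assay.
Compound 2 `O=c1ccoc2cc(OCc3cn(Cc4ccccc4Br)nn3)ccc12` in this assay gives > 100000 nM, again a limit.

Among the compounds with values here, compound 1 stands only at the limit; no number is known for it, and the one further value shown is a limit too. The step from compound 1 to compound 2, a step that the two limits leave unreadable from compound 1 to compound 2, cannot be read because both values sit at the limit (the limit of > 100000 nM in this assay, at which 2 of the 2 values shown sit).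

Compound 3 `COc1ccc(Cn2cc(COc3ccc4c(=O)ccoc4c3)nn2)cc1` differs from compound 1 by methoxy in place of cyano on an aromatic carbon. Within the data shown here, no measured step bears on this change; the single step in hand is unreadable, so there is nothing to scale an expectation from other than the position of compound 1 at the limit. For compound 3 the expected step is a step that the limit leaves unreadable from compound 1 to compound 3, none beyond the scatter, and the value is most likely to come back as a limit once more. The estimate for compound 3 in this assay is 150000 nM, with a range from 40000 nM to 600000 nM.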

Compound 3, half-maximal inhibitory concentration: 20400 nM
Beside the measured number, compound 3's estimate is 7.4-fold (0.87 log units) above it, outside the stated range (below it).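

Within the data shown here, compound 3 is the first compound to give a number in this assay, which shows that the substituent on this aromatic carbon can move the read-out off the limit. Methoxy in place of cyano gives an at least 4.9-fold lower number from compound 1 to compound 3 (0.69 log units; beyond the scatter), and 4-methoxyphenyl in place of 2-bromophenyl gives an at least 4.9-fold lower number from compound 2 to compound 3 (0.69 log units; beyond the scatter). Both steps start from a limit and so fix only a minimum size, while the step between the two limit compounds cannot be read: the limit of > 100000 nM in this assay, at which 2 of the 3 values shown sit.

Still open, from the compounds shown here alone, is whether the shift is specific to methoxy or would also appear with a hydroxyl, an amine or a longer alkoxy chain such as ethoxy on the same carbon. Also open, going by these compounds, is whether methoxy elsewhere on this ring would give a similar value.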